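Replacing the dihydroxyphenyl tail with a sulfobenzyl tail

The source may report more compounds than this note shows. Statements on the series, on what has been measured and on what is new or still open speak of the compounds shown alone.

Of the compounds shown here, three sharing one core have been measured in a functional assay on HL-60 cells (Homo sapiens) for antiproliferative activity, read by MTT assay, with a stated time of 48 h; on this read-out lower numbers stand for stronger inhibition and higher numbers for weaker inhibition. Compound 1 `COC1=C(OC)C(=O)C(CCCCCCCCCCN(Cc2ccccc2)Cc2ccccc2)=C(C)C1=O` reaches only the limit of the assay, > 200000 nM, so no number is known for it. Compound 2 `COC1=C(OC)C(=O)C(CCCCCCCCCCn2ccnc2)=C(C)C1=O` gives 15000 nM, and compound 3 `COC1=C(OC)C(=O)C(CCCCCCCCCCOc2cc(O)cc(O)c2)=C(C)C1=O` gives 63000 nM. Within the data shown here, compound 3 therefore holds the highest of the two numbers that were obtained; the only measured step leading to it is a 4.2-fold higher number from compound 2 to compound 3 (0.62 log units; beyond the scatter), and the limit of > 200000 nM in this assay, at which 1 of the 3 values shown sits, shows that the chain end can also remove all detectable inhibition.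

Compound 4 `COC1=C(OC)C(=O)C(CCCCCCCCCCOCc2cccc(S(=O)(=O)O)c2)=C(C)C1=O` differs from compound 3 by 3-sulfobenzyl in place of 3,5-dihydroxyphenyl on an oxygen on a saturated carbon. Among the measured compounds shown here, no measured step changes the group on the oxygen in this way, so none bears directly on the change; the closest comparison, the step from compound 2 to compound 3, shows that exchanging the chain end moves the number by a modest amount, and compound 1 shows that it can push the number to the limit.

The estimate for compound 4 is therefore close to compound 3, with a wide range allowing for weaker inhibition: the expected step is a 1.3-fold higher number from compound 3 to compound 4 (0.10 log units; within the scatter). Compound 4 is estimated at 80000 nM, between 20000 nM and 300000 nM.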

Compound 4, half-maximal inhibitory concentration: 120000 nM
Estimate against measurement, compound 4: 1.5-fold (0.18 log units) below; the measured number falls inside the stated range.
By their numbers in this assay, from the lowest: compound 2; then compounds 3 and 4 (each within the scatter of the next). At a limit, above all of these: compound 1.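

In this assay, putting 3-sulfobenzyl in place of 3,5-dihydroxyphenyl on the chain-end oxygen gives a 1.9-fold higher number from compound 3 to compound 4 (0.28 log units; within the scatter), so this read-out does not separate the two tails. Among these compounds, this is the first measured pair in which both chain ends are joined through an oxygen, and a sulfur-bearing group with more heavy atoms takes the place of a ring carrying two hydroxyl groups without a difference beyond the usual scatter, whereas the earlier exchange of the chain end gave a 4.2-fold higher number from compound 2 to compound 3 (0.62 log units; beyond the scatter). Compound 4 still gives a measured number, and only compound 1 remains at a limit of the assay: the limit of > 200000 nM in this assay, at which 1 of the 4 values shown sits.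

Open, going by these compounds, is whether a plain benzyl group on the same oxygen would also stay within the scatter of compound 3, which would show whether the ring substituents matter at all at this position, and whether a carboxylic acid in place of the sulfo group would do the same. Also open is whether a shorter chain would change the numbers of these oxygen-linked compounds, since every compound shown carries the same chain length.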